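The source may report more compounds than this note shows. Statements on the series, on what has been measured and on what is new or still open speak of the compounds shown alone.

Three measured members of the series, compound 1 `CCc1ccc2nc(C(=O)Nc3c(F)cc(-c4cccc(F)c4)cc3F)c(C)c(C(=O)O)c2c1`, compound 2 `Cc1c(C(=O)Nc2c(F)cc(-c3cccc(F)c3)cc2F)nc2ccc(F)cc2c1C(=O)O` and compound 3 `COc1ccc2nc(C(=O)Nc3c(F)cc(-c4cccc(F)c4)cc3F)c(C)c(C(=O)O)c2c1`, all sit at the bottom of a functional assay on Hep 3B2 cells (Homo sapiens) for antiproliferative activity, read by MTT assay, with a stated time of 24 h, tested at 0.02 ug/mL; on this read-out lower numbers stand for a weaker effect and higher numbers for a stronger effect at the one concentration tested: compound 1 gives -0.05%, compound 2 gives -0.13% and compound 3 gives -0.57%, the lowest of the three numbers but within the scatter of both others. Compound 4 `Cc1c(C(=O)Nc2c(F)cc(-c3cccc(F)c3)cc2F)nc2ccc(C(F)(F)F)cc2c1C(=O)O` carries trifluoromethyl in place of methoxy on an aromatic carbon. Among the compounds with values here, the steps that bear on this change at the same aromatic carbon are a number 0.1 percentage points lower from compound 1 to compound 2 (within the scatter), a number 0.5 percentage points lower from compound 1 to compound 3 (within the scatter) and a number 0.4 percentage points lower from compound 2 to compound 3 (within the scatter), none of them beyond the scatter. No measurable shift in this assay is therefore expected; the expected step is a number 0.3 percentage points higher from compound 3 to compound 4 (within the scatter). Compound 4 is estimated at -0.3%, with an expected range from -5% to 5%.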

Compound 4, a percentage reported as inhibition, at one concentration (the size of the read-out at that concentration, not a potency): 1.15%
Compound 4: the middle estimate sits 1.5 percentage points below what was measured, and the stated range covers the measured number.
By their numbers in this assay, from the lowest: compounds 3, 2, 1 and 4 (each within the scatter of the next).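

Trifluoromethyl on this aromatic carbon stays within the scatter of all three earlier groups in this assay (a number 1.7 percentage points higher from compound 3 to compound 4 (within the scatter); a number 1.3 percentage points higher from compound 2 to compound 4 (within the scatter); a number 1.2 percentage points higher from compound 1 to compound 4 (within the scatter)). The position has now carried four different groups with no separable read-out, so these compounds cannot be ranked by this change. Nothing at hand bears on the reason for this flat result.

From the compounds shown here alone, whether an amine, a carboxylic acid or a longer chain on this carbon would move the read-out remains open. So does whether the flatness belongs to the position or to the single concentration tested.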